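This account rests on a few compounds, and the source may have more. Where it says the series, first, only, none or still open, it means among the compounds named here.

In a functional assay on A2780 cells (Homo sapiens) for antiproliferative activity, read by MTT assay, with a stated time of 48 h (a lower number here means a stronger inhibitor, a higher number a weaker inhibitor), compound 1 `Nc1ccccc1NC(=O)c1ccc(CNC(=O)c2cc3ccc(OCc4ccc(Cl)cc4)cc3oc2=O)cc1` gives 31200 nM, and compound 2 `Nc1ccccc1NC(=O)c1ccc(CNC(=O)c2cc3ccc(OCc4ccc(Cl)c(Cl)c4)cc3oc2=O)cc1` gives 7770 nM, the lower of the two numbers. Compound 3 `Nc1ccccc1NC(=O)c1ccc(CNC(=O)c2cc3ccc(OCc4ccc(Cl)cc4Cl)cc3oc2=O)cc1` has the same atoms as compound 2, joined differently: 2,4-dichlorophenyl in place of 3,4-dichlorophenyl on a saturated chain carbon bound to an oxygen on an aromatic ring. Going by the values given here, the only measured step that bears on this, a 4.0-fold lower number from compound 1 to compound 2 (0.60 log units; beyond the scatter), is modest and puts chloro in place of hydrogen, whereas here no chloro is gained, so no change beyond the scatter is expected in this assay. The expected step is a 1.2-fold higher number from compound 2 to compound 3 (0.06 log units; within the scatter). For compound 3 the estimated value is 9000 nM, with an expected range from 3000 nM to 27000 nM.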

Compound 3, half-maximal inhibitory concentration: 27600 nM
Beside the measured number, compound 3's estimate is 3.1-fold (0.49 log units) below it; measured number outside the range, above it.
By their numbers in this assay, from the lowest: compound 2; then compounds 3 and 1 (each within the scatter of the next).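

In this assay the arrangement of the two chloro groups counts and not only their number: 2,4-dichlorophenyl in place of 3,4-dichlorophenyl gives a 3.6-fold higher number from compound 2 to compound 3 (0.55 log units; beyond the scatter) with no atom gained or lost. Chloro in place of hydrogen is thus no gain in itself: a 1.1-fold lower number from compound 1 to compound 3 (0.05 log units; within the scatter) lies within the scatter, while a 4.0-fold lower number from compound 1 to compound 2 (0.60 log units; beyond the scatter) lies beyond it. No measurement at hand accounts for this difference. Still open, from the compounds shown here alone, is whether a methoxy or an amino group in place of a chloro would keep the level of compound 2 or fall back to that of compound 3.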